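The source may hold more compounds than are shown below. What is called first, only, known or untested is meant among the compounds shown, and "the series" means these compounds.

Compound 1 `COc1cc(/C=C/S(=O)(=O)Cc2ccc(OC)c([N+](=O)[O-])c2)cc(OC)c1` was examined in a functional assay on HCT-116 cells (Homo sapiens) for cytotoxicity, read by MTT assay, with a stated time of 72 h; a lower number here means a stronger inhibitor of growth, a higher number a weaker inhibitor of growth. In this assay compound 1 gives > 30000 nM, which is a limit of the assay and not a number. Compound 2 `COc1ccc(CS(=O)(=O)CC(=O)Nc2ccccc2)cc1[N+](=O)[O-]` carries the same nitro-bearing arene on a different core; how the two cores differ is not broken down here. In this assay compound 2 gives > 30000 nM, again a limit rather than a measured number. Compound 3 `COc1ccc(CS(=O)(=O)CC(=O)Nc2ccccc2)cc1N` is obtained from compound 2 by amino in place of nitro on an aromatic carbon. In this assay compound 3 gives > 30000 nM, also a limit. The step that the two limits leave unreadable from compound 2 to compound 3 therefore cannot be sized because the limit of > 30000 nM in this assay, at which 3 of the 3 values shown sit, covers both ends of it.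

Among the compounds with values here, compound 4 `COc1cc(/C=C/S(=O)(=O)Cc2ccc(OC)c(N)c2)cc(OC)c1` differs from compound 1 by amino in place of nitro on an aromatic carbon, the same change, at the same place, as the one that separates compound 2 and compound 3, and it is still to be measured in this assay. Within the data shown here, the only precedent for this change, the step that the two limits leave unreadable from compound 2 to compound 3, gave no readable size, so for compound 4 the step is expected to be a number no higher from compound 1 to compound 4 (the limit leaves the size open). With all three measured values sitting at the limit and nothing showing that the amino compound moves off it, compound 4 is estimated at 30000 nM, most likely somewhere between 3000 nM and 100000 nM, with a real chance that only a limit is reported.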

Compound 4, concentration for 50% growth inhibition: 540 nM
For compound 4 the middle estimate is 56-fold (1.74 log units) above the measured one, outside the stated range (below it).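

In this assay, amino in place of nitro on an aromatic carbon gives an at least 55-fold lower number from compound 1 to compound 4 (1.74 log units; beyond the scatter), so on the core of compound 1 this change takes a compound that sat at a limit of the assay to a measured value. Within the data shown here, on the core of compound 2 the same change leaves both compounds at a limit and the step cannot be read, so the series shows no case of a measurable gain carrying from one core to the other, and compound 2 and compound 3 show only that the change did not lift that core off the limit. Neither step can be given an exact size, and the two cannot be compared, because one end of each rests on a limit and not on a number: the limit of > 30000 nM in this assay, at which 3 of the 4 values shown sit.

The compounds shown leave open whether the amino group itself is what matters on the core of compound 1, or whether a hydroxyl, an acetamide or a dimethylamino group in the same place would give a similar value. They also leave open how much the core of compound 1 contributes beyond this one change, for instance whether the result would hold with an ethoxy group in place of the methoxy group in the place the change occupies.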